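Methylating the Phenol of a Cell Growth Inhibitor

A few compounds are considered here, and "the series" means these few. Any claim that something is new, unique, unknown or untested is made for them only; others in the source may bear on it.

In a functional assay on RCC4 cells (Homo sapiens) for inhibition, read by XTT assay, with a stated time of 4 days (on this read-out lower numbers stand for stronger inhibition and higher numbers for weaker inhibition), compound 1 `Oc1ccc(Nc2nc(-c3ccncc3)cs2)cc1` gives 5370 nM; this is the only number shown for it, next to one further entry that carries no single figure. For the measured compounds named here, compound 2 `Cc1cccc(Nc2nc(-c3ccnc(-c4ccncc4)c3)cs2)c1` is built differently and in this assay gives 28900 nM; 29500 nM (2 entries); no single step connects it to compound 1, so its readings stand on their own. Compound 3 `COc1ccc(Nc2nc(-c3ccncc3)cs2)cc1` is compound 1 with one change, methyl in place of hydrogen on an oxygen on an aromatic ring, which reads as hydroxy to methoxy. Going by the values given here, no measured pair in this assay shows the effect of this change, so the size of the step is open; the cautious expectation is a step close to the usual scatter, leaning towards weaker inhibition. On that basis compound 3 is estimated at 8000 nM, within a range from 2500 nM to 30000 nM, which means an expected step of a 1.5-fold higher number from compound 1 to compound 3 (0.17 log units; within the scatter).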

Compound 3, half-maximal inhibitory concentration: 14100 nM
Beside the measured number, compound 3's estimate is 1.8-fold (0.25 log units) below it; the measured number falls inside the stated range.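

Until now, nothing showed how inhibition responds to a change at this oxygen on an aromatic ring. In this assay, going from hydroxy to methoxy gives a 2.6-fold higher number from compound 1 to compound 3 (0.42 log units; beyond the scatter), so the hydrogen on that oxygen can be replaced by methyl at a modest cost, and compound 3 still gives a measurable value. A step of this size can be read as more than noise, since repeated readings in this assay can agree closely, as shown by: the several entries of compound 2 in this assay, 28900 nM; 29500 nM (2 entries)

This single step cannot separate the loss of the hydrogen from the arrival of the methyl. Going by these compounds, whether the number keeps rising with a longer chain such as ethoxy, or what an amine would do in place of the hydroxy, remains open.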